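A Saturated Ring Returns to a Urea Amide

The source may hold more compounds than are shown below. What is called first, only, known or untested is meant among the compounds shown, and "the series" means these compounds.

Compound 1, `CC(C)C(=O)N1CCC(NC(=O)Nc2ccc(C(F)(F)F)c(F)c2)CC1`: in a physicochemical assay for solubility, read by mass spectrometry, in phosphate buffer, with a stated time of 24 h, at pH 7.4 (a lower number here means a less soluble compound, a higher number a more soluble compound), compound 1 gives 5.9 ug/mL.
Compound 2, `O=C(Nc1ccc(OC(F)(F)F)cc1)NC1CCN(C(=O)C2CCCOC2)CC1`: in this assay compound 2 gives 94 ug/mL.
Compound 3, `Cc1occc1C(=O)N1CCC(NC(=O)Nc2ccc(OC(F)(F)F)cc2)CC1`: in this assay compound 3 gives 8.6 ug/mL.

Compound 3 stands second highest of these three numbers. Its nearest neighbour is compound 1, whose number lies within the scatter of it, so the two cannot be ranked against each other. Compound 2 lies far above, beyond the scatter.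

Compound 4, `O=C(Nc1ccc(OC(F)(F)F)cc1)NC1CCN(C(=O)C2CCOCC2)CC1`, has not yet been measured. It differs from compound 3 in one place: oxan-4-yl in place of 2-methylfuran-3-yl on a carbonyl carbon.

Among the compounds with values here, one measured step bears on this change: an 11-fold lower number from compound 2 to compound 3 (1.04 log units; beyond the scatter). There the six-membered non-aromatic ring with one hetero atom was exchanged for the five-membered aromatic ring, and the number fell sharply. The move from compound 3 to compound 4 largely reverses that exchange, since oxan-4-yl and oxan-3-yl are both six-membered non-aromatic rings with one hetero atom. A large upward step is therefore expected, a 9.3-fold higher number from compound 3 to compound 4 (0.97 log units; beyond the scatter), ending near the number of compound 2. Compound 4 is expected to give about 80 ug/mL, with a range from 30 ug/mL to 200 ug/mL.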

Compound 4, solubility: 91 ug/mL
Compound 4: middle estimate off by 1.1-fold (0.06 log units), on the low side; the range from low to high includes it.
By their numbers in this assay, from the lowest: compounds 1 and 3 (each within the scatter of the next); then compounds 4 and 2 (each within the scatter of the next).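

In this assay, the earlier fall of an 11-fold lower number from compound 2 to compound 3 (1.04 log units; beyond the scatter) now has a matching rise of an 11-fold higher number from compound 3 to compound 4 (1.02 log units; beyond the scatter) when oxan-4-yl stands on the carbonyl carbon, so a second six-membered non-aromatic ring gives a number far from that of the five-membered aromatic ring. The leaving and entering groups in that rise have the same counts of heavy atoms, carbon, oxygen, hydrogen-bond donors and hydrogen-bond acceptors, so the large step occurs with all of those counts unchanged, while the ring itself differs in size and in being aromatic or not. Oxan-3-yl and oxan-4-yl cannot be told apart at this place, as a 1.0-fold lower number from compound 2 to compound 4 (0.01 log units; within the scatter) shows, so the position of the ring oxygen in these two groups makes no readable difference here.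

Nothing measured here shows what lies behind the large step. The compounds shown leave open whether cyclohexyl, with no ring oxygen, or piperidin-4-yl, with a ring nitrogen in its place, would give a number close to those of compound 2 and compound 4 or one close to that of compound 3.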